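Benzyl to 3,7-dimethylocta-2,6-dien-1-yl: working notes on the series

A few compounds are considered here, and "the series" means these few. Any claim that something is new, unique, unknown or untested is made for them only; others in the source may bear on it.

Among the measured compounds shown here, in a functional assay on BT-474 cells (Homo sapiens) for inhibition, read by fluorescence, with a stated time of 72 h (a higher number here means a weaker inhibitor of growth, a lower number a stronger inhibitor of growth), compound 2 `N[C@H]1CC[C@H](Nc2nc(Nc3cccc(Cl)c3)c3ncn(Cc4ccccc4)c3n2)CC1` gives 10200 nM, the higher of the two numbers so far, while compound 1 `CC(C)CCn1cnc2c(Nc3cccc(Cl)c3)nc(N[C@H]3CC[C@H](N)CC3)nc21` gives 3800 nM as its nearest neighbour. Compound 3 `CC(C)=CCC/C(C)=C/Cn1cnc2c(Nc3cccc(Cl)c3)nc(N[C@H]3CC[C@H](N)CC3)nc21` is the next to read, and its difference from compound 2 is 2,6-dimethylhepta-1,5-dien-1-yl in place of phenyl on a saturated chain carbon bound to an aromatic nitrogen. In words, this is 2,6-dimethylhepta-1,5-dien-1-yl in place of phenyl on a saturated chain carbon bound to an aromatic nitrogen.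

For the measured compounds named here, one measured step bears on this change: a 2.7-fold higher number from compound 1 to compound 2 (0.43 log units; beyond the scatter), a modest step that came with phenyl in place of isobutyl at the same place. Compound 3 also loses that phenyl and, like compound 1, has no ring in the entering group. Going by the values given here, a return towards the number of compound 1 at 3800 nM is therefore expected, though no measured compound carries a chain of this size, so the range stays wide.

The expected change is a 2.6-fold lower number from compound 2 to compound 3 (0.41 log units; beyond the scatter), a modest move to a lower number. For compound 3 the estimate is 4000 nM, with 1500 nM to 11000 nM as the expected range in this assay for this series.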

Compound 3, concentration for 50% growth inhibition: 4300 nM
For compound 3 the middle estimate is 1.1-fold (0.03 log units) below the measured one, within the range that was stated.
By their numbers in this assay, from the lowest: compounds 1 and 3 (each within the scatter of the next); then compound 2.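

At this place, on a saturated chain carbon bound to an aromatic nitrogen, this assay gives a 2.4-fold lower number from compound 2 to compound 3 (0.38 log units; beyond the scatter) when 2,6-dimethylhepta-1,5-dien-1-yl replaces phenyl, so a second group with no ring also parts from the higher number of compound 2. The comparison with the isobutyl compound gives a 1.1-fold higher number from compound 1 to compound 3 (0.05 log units; within the scatter) and so does not separate the two ring-free groups, although only the 2,6-dimethylhepta-1,5-dien-1-yl group carries double bonds outside aromatic rings. Among these three compounds, the phenyl group of compound 2 alone stands apart, with no compound going against that reading, but nothing available explains these steps.

The three groups do not show whether the difference belongs to aromatic character, to any ring, or to phenyl alone, and a cyclohexyl or pyridyl group at this place would separate those readings. Nor do they show whether the double bonds of the 3,7-dimethylocta-2,6-dien-1-yl group matter, or how this place responds to a saturated 3,7-dimethyloctyl chain or to a chain ending in an amine or a carboxylic acid.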